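The source may hold more compounds than are shown below. What is called first, only, known or untested is meant among the compounds shown, and "the series" means these compounds.

Working notes on the series.

Compound 1 `CC(/C=C/CC(C)CCCC(C)C)=C\C(=O)OCc1ccccc1` stands highest of the three measured compounds in a physicochemical assay for lipophilicity (on this read-out higher numbers stand for higher lipophilicity and lower numbers for lower lipophilicity), where compound 1 gives 7.87. The nearest measured number belongs to compound 3 `CCOC(=O)/C=C(C)/C=C/CC(C)CCC(OC)C(C)C`, which in this assay gives 5.54, and the lowest to compound 2 `CCOC(=O)/C=C(C)/C=C/CC(C)CCCC(C)(C)O`, which gives 4.65 in this assay. For the measured compounds named here, the only step between two compounds that differ in one place is a number 0.89 log units higher from compound 2 to compound 3 (beyond the scatter); it concerns the far end of the saturated chain and leaves the ester end untouched.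

Compound 4 `CCCC(=O)/C=C(C)/C=C/CC(C)CCCC(C)C` is still to be measured. Against compound 1 the change is propyl in place of benzyloxy on a carbonyl carbon. Going by the values given here, no measured pair touches the carbonyl carbon, so nothing bears directly on this step; the step between compound 2 and compound 3 shows only that a single-site change on the chain moved this assay by well under a unit, and cannot be carried over to the ester end. The change removes an aromatic ring together with an oxygen and puts in a shorter chain of three carbons, so a drop in this assay beyond the scatter is expected, with the step from compound 1 to compound 4 estimated at a number 1.07 log units lower from compound 1 to compound 4 (beyond the scatter). Compound 4 is therefore expected to give about 6.8 in this assay, within a range of 6.1 to 7.5.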

Compound 4, partition coefficient: 6.81
Beside the measured number, compound 4's estimate is 0.01 log units below it, and the stated range covers the measured number.
By their numbers in this assay, from the lowest: compound 2; then compound 3; then compound 4; then compound 1.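

The carbonyl carbon now has a measured step of its own in this assay: a number 1.06 log units lower from compound 1 to compound 4 (beyond the scatter), beyond the scatter, with propyl in place of benzyloxy and the rest of the molecule unchanged. For the compounds shown here, until now, the only single-site step was on the saturated chain, a number 0.89 log units higher from compound 2 to compound 3 (beyond the scatter), so this result shows that a change at the ester end also moves this assay beyond the scatter. The change removes the six-membered aromatic ring, the oxygen and the hydrogen-bond acceptor together, and no information on the origin of the step is available.

With a single step at this position, the compounds shown do not separate the contributions of the ring, the oxygen and the number of heavy atoms. On these data alone, a phenyl group or a pentyl chain on the same carbonyl carbon, or an amine in place of benzyloxy, would each test a different part of this change, and how far the step holds on a different chain end also remains open.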